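The compounds below may be only part of what the source reports. "The series", "measured", "known", "first", "only" and "open" are said of these compounds alone.

Measured compounds:
- compound 1, `COc1ccc2[nH]c(C(=O)N3CC(=O)N(Cc4ccccc4)[C@@H](CN4C(=O)c5ccccc5C4=O)C3)cc2c1`: 41000 nM
- compound 2, `COc1ccc2[nH]c(C(=O)N3CC(=O)N(Cc4ccccc4)[C@@H](CN4CCN(c5ccc(F)cc5)CC4)C3)cc2c1`: > 30000 nM

The two compounds share a core and differ in the group attached to the side chain. In an ADME assay on Vero cells (Chlorocebus sabaeus) for cytotoxicity, with a stated time of 7 days (on this read-out higher numbers stand for lower toxicity in this test and lower numbers for higher toxicity in this test), compound 1 gives 41000 nM. For compound 2 the result in this assay is a limit of the assay, > 30000 nM, not a number. Where compound 2 stands is therefore known only as the limit of > 30000 nM in this assay, at which 1 of the 2 values shown sits, so its toxicity in this assay is low by this read-out, but no exact figure is available, and no step between the two measured compounds is set out.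

Compound 3, `COc1ccc2[nH]c(C(=O)N3CC(=O)N(Cc4ccccc4)[C@@H](CN4CCN(c5ccccn5)CC4)C3)cc2c1`, differs from compound 2 by pyridin-2-yl in place of 4-fluorophenyl on an amine nitrogen in a ring. Nothing in the measured pair shows how this exchange affects the read-out. Compound 3 is expected to behave much like compound 2, so the step that the limit leaves unreadable from compound 2 to compound 3 is expected to lie within the scatter. For compound 3 the value in this assay is expected to be about 40000 nM. The range for compound 3 is expected to run from 18000 nM to 90000 nM, with a fair chance that only a limit is reported.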

Compound 3, half-maximal cytotoxic concentration: > 30000 nM
Compound 3: only a limit was reported (the forecaster's own chance of this, stated with the estimate: 60%); the middle value does not contradict the limit.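

In this assay compound 3 gives > 30000 nM, a limit of the assay and not a number. Within the data shown here, no step can therefore be read from compound 2 to compound 3 or from compound 1 to compound 3. The compounds shown leave open whether pyridin-2-yl in place of 4-fluorophenyl changes this read-out at all.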